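Swapping the group on the sulfonyl sulfur and liver clearance

The compounds below may be only part of what the source reports. "The series", "measured", "known", "first", "only" and "open" are said of these compounds alone.

Compound 2 `CC(=O)N1CCC(S(=O)(=O)c2ccc(CNC(=O)N3Cc4ccncc4C3)cc2)CC1` carries a 1-acetylpiperidin-4-yl group on its sulfonyl sulfur. Going by the values given here, in an ADME assay on microsomes from liver (Homo sapiens) for pharmacokinetics, read by LC-MS, with a stated time of 60 min, tested at 1 uM (on this read-out lower numbers stand for slow clearance and higher numbers for fast clearance), compound 2 gives 6 mL/min/kg and so shows the lowest of the two numbers measured so far. Its nearest neighbour is compound 1 `CCCn1cc(S(=O)(=O)c2ccc(CNC(=O)N3Cc4ccncc4C3)cc2)cn1` with a 1-propyl-1H-pyrazol-4-yl group on the sulfonyl sulfur instead; in this assay compound 1 gives 11 mL/min/kg in the same test. The step of a 1.8-fold lower number from compound 1 to compound 2 (0.26 log units; within the scatter) lies within the scatter, so these two groups on the sulfonyl sulfur are not told apart by this read-out.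

Compound 3 `CN1CCN(S(=O)(=O)c2ccc(CNC(=O)N3Cc4ccncc4C3)cc2)CC1` has not been measured yet. It differs from compound 2 at the same place, namely 4-methylpiperazin-1-yl in place of 1-acetylpiperidin-4-yl on a sulfonyl sulfur on the sulfonyl sulfur. Among the compounds with values here, the only measured step at this position is a 1.8-fold lower number from compound 1 to compound 2 (0.26 log units; within the scatter) and it was small, so a further change here is expected to move the number little, if at all, beyond the scatter. The estimated step of a 1.2-fold higher number from compound 2 to compound 3 (0.07 log units; within the scatter) is expected to stay within the scatter. Compound 3 is therefore expected to give about 7 mL/min/kg in this assay with a range from 3.5 mL/min/kg to 14 mL/min/kg.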

Compound 3, clearance: 9 mL/min/kg
The estimate for compound 3 lay 1.3-fold (0.11 log units) below the measured number, within the range that was stated.
By their numbers in this assay, from the lowest: compounds 2, 3 and 1 (each within the scatter of the next).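

With a third group on the sulfonyl sulfur, the picture of this position widens: in this assay, 4-methylpiperazin-1-yl cannot be told apart from 1-acetylpiperidin-4-yl (a 1.5-fold higher number from compound 2 to compound 3 (0.18 log units; within the scatter)) or from 1-propyl-1H-pyrazol-4-yl (a 1.2-fold lower number from compound 1 to compound 3 (0.09 log units; within the scatter)). Before, a single pair supported this reading; now all three groups lie within the scatter of one another, even though the new group has two hetero atoms in its six-membered ring, lacks the double bond outside aromatic rings found in 1-acetylpiperidin-4-yl, and is smaller by the heavy-atom counts. Among these three compounds, then, clearance in this test stays much the same whichever of these groups is attached, and none of the three goes against that, though nothing measured here explains it.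

Still open, going by these compounds, is whether any group on the sulfonyl sulfur can move the number beyond the scatter, for instance one carrying a carboxylic acid, a primary amine or a long alkyl chain. The compounds shown also share the rest of their structure, so they cannot say how a change elsewhere in the shared core would affect clearance.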